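A few compounds are considered here, and "the series" means these few. Any claim that something is new, unique, unknown or untested is made for them only; others in the source may bear on it.

In a functional assay on HeLa cells (Homo sapiens) for antiproliferative activity, read by MTT assay, with a stated time of 48 h (a higher number here means a weaker inhibitor, a lower number a stronger inhibitor), compound 1 `Clc1ccc2[nH]c(-c3cn(-c4ccccc4)nc3-c3ccccc3)nc2c1` gives 3480 nM, compound 2 `Fc1ccc(-c2nn(-c3ccccc3)cc2-c2nc3cc(Cl)ccc3[nH]2)cc1` gives 2770 nM and compound 3 `Clc1ccc(-c2nn(-c3ccccc3)cc2-c2nc3cc(Cl)ccc3[nH]2)cc1` gives 1630 nM. Compound 3 separates from compound 1 but not from compound 2. The two steps are a 2.1-fold lower number from compound 1 to compound 3 (0.33 log units; beyond the scatter) and a 1.7-fold lower number from compound 2 to compound 3 (0.23 log units; within the scatter). The remaining step, a 1.3-fold lower number from compound 1 to compound 2 (0.10 log units; within the scatter), is also small.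

Compound 4 `COc1ccc(-c2nn(-c3ccccc3)cc2-c2nc3cc(Cl)ccc3[nH]2)cc1` differs from compound 3 by methoxy in place of chloro on an aromatic carbon, para to a large group. Among the compounds with values here, no measured compound carries methoxy, so these three steps give only a rough guide to size. A small rise in this assay is expected, probably within the scatter. The expected change is a 1.5-fold higher number from compound 3 to compound 4 (0.17 log units; within the scatter). Compound 4 is estimated at 2400 nM, with an expected range of 1000 nM to 5500 nM.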

Compound 4, half-maximal inhibitory concentration: 1290 nM
The estimate for compound 4 lay 1.9-fold (0.27 log units) above the measured number; measured number inside the range.
By their numbers in this assay, from the lowest: compounds 4, 3, 2 and 1 (each within the scatter of the next, the first and the last beyond it).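

At the position para to a large group, methoxy separates from fluoro (a 2.1-fold lower number from compound 2 to compound 4 (0.33 log units; beyond the scatter)) and from hydrogen (a 2.7-fold lower number from compound 1 to compound 4 (0.43 log units; beyond the scatter)) in this assay, but not from chloro (a 1.3-fold lower number from compound 3 to compound 4 (0.10 log units; within the scatter)). Methoxy thus joins chloro as a group that separates from hydrogen, which fluoro in compound 2 does not. The change from 4-chlorophenyl to 4-methoxyphenyl brings in a hydrogen-bond acceptor with no step beyond the scatter.

Going by these compounds, whether an amine, a carboxylic acid or a longer chain at this position would stay in this range remains open. Nothing available accounts for these steps.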